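Pentylthio amidine series: T-type channel inhibition notes

The compounds below may be only part of what the source reports. "The series", "measured", "known", "first", "only" and "open" are said of these compounds alone.

Measured so far:
compound 1 `O=C(CC1c2ccccc2N=C(SCCCCCN2CCCC2)N1c1ccc(-c2ccc(F)cc2)cc1)NCc1ccc(F)cc1` — 35.1%
compound 2 `O=C(CC1c2ccccc2N=C(SCCCCCN2CCCC2)N1c1ccccc1)NCc1ccc(F)cc1` — 22.1%
compound 3 `CN(C)CCCCCSC1=Nc2ccccc2C(CC(=O)NCc2ccc(F)cc2)N1c1ccccc1` — "not active" (no number reported)

In an assay on cells for inhibition of Voltage-dependent T-type calcium channel subunit alpha-1I (Homo sapiens), read by patch clamp, tested at 10 uM (a higher number here means more inhibition at the concentration tested (going by the name of the read-out), a lower number less inhibition), compound 2 gives 22.1% and compound 1 gives 35.1%; the step is a number 13 percentage points higher from compound 2 to compound 1 (beyond the scatter), made by the change (4-fluorophenyl in place of hydrogen on an aromatic carbon). Compound 3 differs from compound 2 in the core only, by dimethylamino in place of pyrrolidin-1-yl on a saturated chain carbon, five bonds along the chain from a sulfur, and in this assay compound 3 is reported as "not active" (no number reported), so no number stands for it.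

Compound 4 `CN(C)CCCCCSC1=Nc2ccccc2C(CC(=O)NCc2ccc(F)cc2)N1c1ccc(-c2ccc(F)cc2)cc1` is not yet measured. It differs from compound 3 by 4-fluorophenyl in place of hydrogen on an aromatic carbon, the same change as that from compound 2 to compound 1, at the same place. Among the compounds with values here, the step of a number 13 percentage points higher from compound 2 to compound 1 (beyond the scatter) is the only guide to its size, and it is modest; since compound 3 starts from no reported activity, the expectation for compound 4 rests on adding a step of that size to a low starting point. Compound 4 is therefore estimated at 12% in this assay, between 0% and 30%, with a real chance that only "not active" is reported again.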

Compound 4, a percentage reported as inhibition, at one concentration (the size of the read-out at that concentration, not a potency): 92%
The estimate for compound 4 lay 80 percentage points below the measured number; measured number above the stated range.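

In this assay, dimethylamino in place of pyrrolidin-1-yl on the core of compound 1 gives a number 56.9 percentage points higher from compound 1 to compound 4 (beyond the scatter), so on this core the smaller amine carries a large gain. The same change on the core of compound 2 does not repeat this in any readable form: compound 2 gives 22.1% and compound 3 is reported as "not active" (no number reported), so the printed values show no gain there and the effect of the change depends on the core it is placed on. The steps that involve compound 3 cannot be read, which leaves a single numbered pair that gives the size of the change on one core only and sets no rule for others, and nothing at hand bears on why the two cores part ways.

Open, as far as these compounds go, is whether the result on the core of compound 4 extends to other amines at the chain end, such as diethylamino or piperidin-1-yl, or to a butyl or hexyl chain in place of the pentyl chain. Also open, from the compounds shown here alone, is whether a phenyl or 4-chlorophenyl group in place of 4-fluorophenyl keeps the same level of inhibition.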